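From 1H-indol-1-yl to 2,3-dihydro-1H-indol-1-yl in compound 1

A few compounds are considered here, and "the series" means these few. Any claim that something is new, unique, unknown or untested is made for them only; others in the source may bear on it.

In a physicochemical assay for lipophilicity, using the shake flask method, in phosphate buffer, measured as octanol-water partition, with a stated time of 2 h, at pH 7.4, tested at 1 uM (on this read-out lower numbers stand for lower lipophilicity and higher numbers for higher lipophilicity), compound 1 (`OC[C@H]1O[C@H](Oc2ccc(-n3ccc4ccccc43)cc2Cl)[C@@H](O)[C@@H](O)[C@@H]1O`) gives 1.8. That is the second highest of three numbers, with compound 2 (`COC(=O)c1ccc2c(ccn2-c2ccc(O[C@H]3O[C@H](CO)[C@@H](O)[C@H](O)[C@@H]3O)c(Cl)c2)c1`) at 2.8 and compound 3 (`O=C(O)c1ccc2c(ccn2-c2ccc(O[C@H]3O[C@H](CO)[C@@H](O)[C@H](O)[C@@H]3O)c(Cl)c2)c1`) at 1.1. The next compound, compound 4 (`OC[C@H]1O[C@H](Oc2ccc(N3CCc4ccccc43)cc2Cl)[C@@H](O)[C@@H](O)[C@@H]1O`), carries 2,3-dihydro-1H-indol-1-yl in place of 1H-indol-1-yl on an aromatic carbon.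

For the measured compounds named here, no measured step makes this exchange, so the three available steps bear on it only loosely. Methoxycarbonyl in place of hydrogen on an aromatic carbon gives a number 1.00 log units higher from compound 1 to compound 2 (beyond the scatter), and carboxy in place of that hydrogen gives a number 0.70 log units lower from compound 1 to compound 3 (beyond the scatter). Exchanging the methyl of the ester for hydrogen gives a number 1.70 log units lower from compound 2 to compound 3 (beyond the scatter). Each of these steps changes a substituent, whereas the new exchange adds none, so a much smaller step is expected, one within the scatter, in no confidently known direction. The estimated step is a number 0.10 log units lower from compound 1 to compound 4 (within the scatter). For compound 4 the estimated value in this assay is 1.7, with an expected range from 1.2 to 2.2.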

Compound 4, distribution coefficient: 2.8
Estimate against measurement, compound 4: 1.10 log units below; the whole stated range lies below it.
By their numbers in this assay, from the lowest: compound 3; then compound 1; then compounds 2 and 4 (each within the scatter of the next).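

Until now, this assay had moved only when a substituent was added to the 1H-indol-1-yl group or altered on it. Compound 4 shows that no added substituent is needed at this position: 2,3-dihydro-1H-indol-1-yl in place of 1H-indol-1-yl gives a number 1.00 log units higher from compound 1 to compound 4 (beyond the scatter), although the two groups hold the same heavy atoms and differ in that the five-membered ring is no longer aromatic. Nothing available explains why this exchange moves the number.

The compounds shown leave open whether methoxycarbonyl or carboxy on the 2,3-dihydro-1H-indol-1-yl group would shift the number as they do on the 1H-indol-1-yl group. They also leave open what an open-chain amine such as diethylamino, with no fused ring, would give at this position.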